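The source may report more compounds than this note shows. Statements on the series, on what has been measured and on what is new or still open speak of the compounds shown alone.

Compound 1 `CC(C)(C)OC(=O)N1CCC(c2coc3c(N4CCCc5cc(S(C)(=O)=O)ccc54)ncnc23)CC1` gives 793 nM in a functional assay on cells for agonist activity at Glucose-dependent insulinotropic receptor (Homo sapiens), read by a luciferase reporter, with a stated time of 4 h; on this read-out higher numbers stand for an effect only at larger amounts of compound and lower numbers for an effect already at smaller amounts.
Compound 2 `CCc1cnc(N2CCC(c3coc4c(N5CCc6cc(S(C)(=O)=O)ccc65)ncnc34)CC2)nc1` gives 41 nM.
Compound 3 `CS(=O)(=O)c1ccc2c(c1)CCN2c1ncnc2c(C3CCN(c4ncccn4)CC3)coc12` gives 512 nM.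

Among these three numbers compound 3 holds the second highest; its nearest neighbour is compound 1, within the scatter, and its furthest is compound 2, beyond the scatter. Compound 4 `CC(O)c1cnc(N2CCC(c3coc4c(N5CCc6cc(S(C)(=O)=O)ccc65)ncnc34)CC2)nc1` differs from compound 3 by 1-hydroxyethyl in place of hydrogen on an aromatic carbon. For the measured compounds named here, the one measured step that bears on this change is a 12-fold higher number from compound 2 to compound 3 (1.10 log units; beyond the scatter), where taking ethyl off an aromatic carbon raised the number sharply. Adding 1-hydroxyethyl to compound 3 runs that path back, so a drop of comparable size is expected in this assay, though the hydroxyl leaves some room for a smaller effect. Compound 4 is therefore expected at 65 nM, with a range from 20 nM to 250 nM. This corresponds to an expected step of a 7.9-fold lower number from compound 3 to compound 4 (0.90 log units; beyond the scatter).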

Compound 4, half-maximal effective concentration: 586 nM
For compound 4 the middle estimate is 9.0-fold (0.95 log units) below the measured one; the whole stated range lies below it.
By their numbers in this assay, from the lowest: compound 2; then compounds 3, 4 and 1 (each within the scatter of the next).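

In this assay, 1-hydroxyethyl on this aromatic carbon gives a 1.1-fold higher number from compound 3 to compound 4 (0.06 log units; within the scatter), so this group does not bring the drop that the step between compound 2 and compound 3 pointed to. A hydroxy on the saturated chain carbon alone accounts for a 14-fold higher number from compound 2 to compound 4 (1.16 log units; beyond the scatter), which shows that what ethyl achieves at this position is lost with this single change. Nothing available explains this difference. On these data alone, whether a methoxy group, an amine or a longer chain such as propyl at this carbon would follow ethyl or 1-hydroxyethyl remains open.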